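The source may report more compounds than this note shows. Statements on the series, on what has been measured and on what is new or still open speak of the compounds shown alone.

Measured so far in an ADME assay on MT4 cells (Homo sapiens) for cytotoxicity, read by MTT assay, with a stated time of 96 h; on this read-out higher numbers stand for lower toxicity in this test and lower numbers for higher toxicity in this test:
- compound 1, `O=[N+]([O-])c1ccc(-c2nc3cc(C(F)(F)F)ccc3[nH]2)c([N+](=O)[O-])c1`: 9000 nM
- compound 2, `CC(=O)Nc1ccc(-c2nc3ccccc3[nH]2)cc1`: 100000 nM
- compound 3, `CC(=O)Nc1ccc(-c2nc3cc(C(F)(F)F)ccc3[nH]2)cc1`: 19000 nM

Compound 1 has the lowest of the three numbers in this assay, and compound 2 the highest; the gap between them lies beyond the scatter. Compounds 1 and 3 share no single counted difference: the difference between the two cores is not broken down here.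

One change is made twice in the series. From compound 3 to compound 2 it is hydrogen in place of trifluoromethyl on an aromatic carbon, and it gives a 5.3-fold higher number from compound 3 to compound 2 (0.72 log units; beyond the scatter). The same change, at the same place, turns compound 1 into compound 4, `O=[N+]([O-])c1ccc(-c2nc3ccccc3[nH]2)c([N+](=O)[O-])c1`, namely (hydrogen in place of trifluoromethyl on an aromatic carbon).

Compound 4 is not yet measured in this assay. If the change acts as it did between compound 3 and compound 2, the number for compound 4 is expected to rise from that of compound 1 by about a 5.0-fold higher number from compound 1 to compound 4 (0.70 log units; beyond the scatter), because the earlier step of a 5.3-fold higher number from compound 3 to compound 2 (0.72 log units; beyond the scatter) points that way. On that basis compound 4 is estimated at 45000 nM, most likely between 18000 nM and 110000 nM; this rests on one prior step only.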

Compound 4, half-maximal cytotoxic concentration: 7000 nM
Beside the measured number, compound 4's estimate is 6.4-fold (0.81 log units) above it, and the stated range ends above it.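

In this assay, hydrogen in place of trifluoromethyl on an aromatic carbon does not carry over from one core to the other, and the two steps differ: the same change on two cores in this assay, a 5.3-fold higher number (0.72 log units; beyond the scatter) from compound 3 to compound 2 and a 1.3-fold lower number (0.11 log units; within the scatter) from compound 1 to compound 4, 6.8-fold (0.83 log units) apart, beyond the scatter of two such steps. On the core of compound 1 the change gives a 1.3-fold lower number from compound 1 to compound 4 (0.11 log units; within the scatter), so no shift can be read there, whereas a shift beyond the scatter was seen on the core of compound 3. This does not show why the two cores part or how the change would behave on a third core; the comparison rests on a single pair of compounds per core.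

The compounds shown leave open which of the differences between the two cores decides whether the change registers, as no compound here separates the nitro groups of compound 1 from the rest of that core. Also open, on these data alone, is how another group at the same place, such as chlorine, a nitrile or a carboxylic acid, would read on either core.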